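This account rests on a few compounds, and the source may have more. Where it says the series, first, only, none or still open, it means among the compounds named here.

The two compounds already measured share one core and differ at both ends. Compound 1 `CCN(CC)S(=O)(=O)c1ccc(S(=O)(=O)N2CCC[C@@H](C(=O)NC3CN(C(=O)C4CC4)C3)C2)cc1` carries a diethylsulfamoyl group on the aryl ring and an azetidine amide; in a functional assay on MIA PaCa-2 cells (Homo sapiens) for inhibition, read by MTT assay, with a stated time of 7 days (a higher number here means a weaker inhibitor, a lower number a stronger inhibitor), compound 1 gives 2800 nM. Compound 2 `CCN(CC)C(=O)c1ccc(S(=O)(=O)N2CCC[C@@H](C(=O)N3CCN(c4nc(C(C)C)no4)CC3)C2)cc1` instead carries a diethylcarbamoyl group and a piperazine amide bearing an isopropyl-oxadiazole; in this assay compound 2 gives 100 nM. Compound 2 thus stands with the lowest of the two numbers, and its gap to compound 1 lies beyond the usual scatter. Since the two differ in two places, the two values alone do not show which change carries the gap.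

Compound 3 `CCNS(=O)(=O)c1ccc(S(=O)(=O)N2CCC[C@@H](C(=O)N3CCN(c4nc(C(C)C)no4)CC3)C2)cc1` keeps the piperazine amide of compound 2 and changes only the aryl substituent: ethylsulfamoyl in place of diethylcarbamoyl on an aromatic carbon, on an aromatic carbon para to a large group. Going by the values given here, no measured pair isolates this change, so the direction rests only on compound 2 and the change itself. A modest weakening is expected, with the step from compound 2 to compound 3 in this assay estimated at a 2.5-fold higher number from compound 2 to compound 3 (0.40 log units; beyond the scatter), though a result within the scatter would not surprise. For compound 3 the estimated value in this assay is 250 nM, within a range of 60 nM to 1200 nM.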

Compound 3, half-maximal inhibitory concentration: 3300 nM
Compound 3: the middle estimate sits 13-fold (1.12 log units) below what was measured; the whole stated range lies below it.
By their numbers in this assay, from the lowest: compound 2; then compounds 1 and 3 (each within the scatter of the next).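

The aromatic carbon para to a large group is not an indifferent place in this series: with the piperazine amide held fixed, this assay gives a 33-fold higher number from compound 2 to compound 3 (1.52 log units; beyond the scatter) for this single exchange. Going by these compounds alone, this is the first pair that differs in one place only, so it shows what compounds 1 and 2 could not, that the aryl substituent alone can carry a large gap beyond the scatter. Diethylcarbamoyl, with no hydrogen-bond donor and one acceptor, gives way here to ethylsulfamoyl, with one donor and two acceptors, but no measurement shown accounts for the weaker result.

The exchange alters several things at once, the carbonyl giving way to a sulfonyl, one ethyl going and a nitrogen hydrogen coming in, so the compounds shown leave open which of these carries the step. From the compounds shown here alone, an ethylcarbamoyl group or a diethylsulfamoyl group at this same place on the piperazine amide would separate them, and it also remains open whether the step would hold with the azetidine amide of compound 1.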